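The compounds below may be only part of what the source reports. "The series", "measured", "known", "first", "only" and "open" are said of these compounds alone.

Compound 3 `COc1cc(C(=O)O)ccc1OCCCCOc1ccc(C(=O)CC(C)C)c(O)c1C` stands lowest of the two numbers obtained in an assay on HEK293 cells for positive allosteric modulation of metabotropic glutamate receptor 3 (Rattus norvegicus), read by thallium flux, with a stated time of 2.5 min (on this read-out higher numbers stand for an effect only at larger amounts of compound and lower numbers for an effect already at smaller amounts), giving 614 nM. Compound 1 `Cc1cc(C(=O)O)ccc1OCCCCOc1ccc(C(=O)CC(C)C)c(O)c1C` gives 1850 nM in this assay, and the step of a 3.0-fold lower number from compound 1 to compound 3 (0.48 log units; beyond the scatter) shows that methoxy brought the number down. Compound 2 `Cc1c(OCCCCOc2ccc(C(=O)O)cc2F)ccc(C(=O)CC2CCCC2)c1O` reaches only the limit of this assay, > 10000 nM, as noted in the limit of > 10000 nM in this assay, at which 1 of the 3 values shown sits. Compound 4 `Cc1c(OCCCCOc2ccc(C(=O)O)cc2F)ccc(C(=O)CC(C)C)c1O` differs from compound 3 by fluoro in place of methoxy on an aromatic carbon. Among the measured compounds shown here, only one measured step bears on this change, the one from compound 1 to compound 3, and since the methoxy gained there is now removed while compound 2, which also carries fluoro, reaches only a limit, a clearly higher number is expected for compound 4. Compound 4 in this assay is estimated at 3500 nM, within 1200 nM to 10000 nM. This corresponds to an expected step of a 5.7-fold higher number from compound 3 to compound 4 (0.76 log units; beyond the scatter).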

Compound 4, half-maximal effective concentration: 1420 nM
Compound 4: middle estimate off by 2.5-fold (0.39 log units), on the high side; measured number inside the range.
By their numbers in this assay, from the lowest: compound 3; then compounds 4 and 1 (each within the scatter of the next). At a limit, above all of these: compound 2.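

In this assay fluoro does not match methoxy on this aromatic carbon, as a 2.3-fold higher number from compound 3 to compound 4 (0.36 log units; beyond the scatter) shows, while a 1.3-fold lower number from compound 1 to compound 4 (0.11 log units; within the scatter) leaves fluoro and methyl level here. Fluoro alone does not bring a limit either: an at least 7.0-fold lower number from compound 2 to compound 4 (0.84 log units; beyond the scatter) comes with isopropyl in place of cyclopentyl on a saturated chain carbon bound to a carbonyl carbon. Compound 2 gives a limit, not a number: the limit of > 10000 nM in this assay, at which 1 of the 4 values shown sits. Going by these compounds, whether ethoxy or hydroxy on this aromatic carbon would stand nearer methoxy or fluoro stays open.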